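Swapping the hydroxycarbamoyl end for a longer amide chain

The compounds below may be only part of what the source reports. "The series", "measured", "known", "first", "only" and "open" are said of these compounds alone.

Compound 1, `CNC(=O)CCCCCCCn1nc(-c2ccc3oc(N)nc3c2)c2c(N)ncnc21`: 8360 nM
Compound 2, `Nc1ncnc2c1c(-c1cnc3[nH]ccc3c1)nn2CCCC(=O)NO`: > 150000 nM
Compound 3, `Nc1ncnc2c1c(-c1cnc3[nH]ccc3c1)nn2CCCCC(=O)NO`: > 150000 nM

The three measured compounds were tested in a functional assay on A549 cells (Homo sapiens) for inhibition, read by MTT assay, with a stated time of 72 h; a higher number here means a weaker inhibitor, a lower number a stronger inhibitor. Compound 1 gives 8360 nM. For compound 2 the assay reports only a limit, > 150000 nM. For compound 3 the result is likewise a limit, > 150000 nM, so compound 3 stands at the edge of what this assay can read, a position it shares with one other value here (the limit of > 150000 nM in this assay, at which 2 of the 3 values shown sit). The step that the two limits leave unreadable from compound 2 to compound 3 is therefore unreadable.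

Compound 4, `CNC(=O)CCCCCCCn1nc(-c2cnc3[nH]ccc3c2)c2c(N)ncnc21`, has not yet been measured. It differs from compound 3 by 3-(methylcarbamoyl)propyl in place of hydroxycarbamoyl on a saturated chain carbon, four bonds along the chain from an aromatic nitrogen. Among the compounds with values here, no measured step covers this change directly, so the expectation rests on compound 1, which carries the same chain on a different core. A readable number rather than a limit is expected for compound 4 because compound 1 gives 8360 nM in this assay. The expected step is an at least 7.5-fold lower number from compound 3 to compound 4 (0.87 log units; beyond the scatter), toward stronger inhibition. Compound 4 is estimated at 20000 nM, with a range from 6000 nM to 80000 nM.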

Compound 4, half-maximal inhibitory concentration: 51000 nM
Beside the measured number, compound 4's estimate is 2.6-fold (0.41 log units) below it; the measured number falls inside the stated range.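

On the shared core, the longer chain ending in a methylamide brings a readable number in this assay, with an at least 2.9-fold lower number from compound 3 to compound 4 (0.46 log units; beyond the scatter) and an at least 2.9-fold lower number from compound 2 to compound 4 (0.46 log units; beyond the scatter). These two steps give only a minimum size, as compound 2 and compound 3 are limits and not numbers: the limit of > 150000 nM in this assay, at which 2 of the 4 values shown sit.

With the chain kept the same, changing the group on the aromatic carbon gives a 6.1-fold higher number from compound 1 to compound 4 (0.79 log units; beyond the scatter), so that group also moves the number in this assay.

The change alters chain length and chain end together, so the compounds shown leave open which of the two matters; a long chain ending in hydroxycarbamoyl, or a short chain ending in a methylamide, would separate them. On these data alone, how a carboxylic acid or an amine at the chain end would compare also remains open.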